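Selenocyanate and diselenide carbamates: alkene on the ester chain

The compounds below may be only part of what the source reports. "The series", "measured", "known", "first", "only" and "open" are said of these compounds alone.

Measured so far:
- compound 1 `CC(C)COC(=O)Nc1ccc([Se][Se]c2ccc(NC(=O)OCC(C)C)cc2)cc1`: 52900 nM
- compound 2 `CCCOC(=O)Nc1ccc([Se]C#N)cc1`: 51900 nM
- compound 3 `Cc1ccc(OC(=O)Nc2ccc([Se][Se]c3ccc(NC(=O)Oc4ccc(C)cc4)cc3)cc2)cc1`: 57000 nM

In a functional assay on HTB-54 cells (Homo sapiens) for cytotoxicity, read by MTT assay, with a stated time of 72 h (a lower number here means a stronger inhibitor of growth, a higher number a weaker inhibitor of growth), compound 1 gives 52900 nM, compound 2 gives 51900 nM and compound 3 gives 57000 nM. The three numbers sit within the usual scatter of one another, so none of the three can be set apart from the others on these data; compound 2 simply belongs to the same band as compound 1 and compound 3, even though the two diselenide compounds and the selenocyanate compound 2 differ widely in their build.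

The next compound, compound 4 `C=CCOC(=O)Nc1ccc([Se]C#N)cc1`, has not yet been measured in this assay. It differs from compound 2 in one place: vinyl in place of ethyl on a saturated chain carbon bound to an oxygen next to a carbonyl group. Within the data shown here, no pair of measured compounds differing in one place is available, so there is no measured step to lean on. Given that the much larger change from compound 2 to compound 1 or compound 3 stays within the scatter, the expectation for this small change is a step of no size beyond the scatter in either direction, a 1.0-fold lower number from compound 2 to compound 4 (0.02 log units; within the scatter) being the estimated step. For compound 4 the estimate is 50000 nM, with a range from 25000 nM to 100000 nM.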

Compound 4, concentration for total growth inhibition: 50100 nM
Beside the measured number, compound 4's estimate is 1.0-fold (0.00 log units) below it; the range from low to high includes it.
By their numbers in this assay, from the lowest: compounds 4, 2, 1 and 3 (each within the scatter of the next).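

In this assay, among these compounds, this is the first change that can be read at a single place: with vinyl in place of ethyl on a saturated chain carbon bound to an oxygen next to a carbonyl group, the result is a 1.0-fold lower number from compound 2 to compound 4 (0.02 log units; within the scatter). At this position, with the selenocyanate held fixed, propoxy and allyloxy cannot be told apart, so the double bond outside aromatic rings brings no measurable difference here. No measured evidence bears on this result.

The compounds shown leave open whether the position accepts larger or more different groups, such as a longer chain, a benzyl group or a terminal amine. They also leave open whether propyl to allyl reads the same way on a diselenide.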